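Methoxy on the aromatic ring: cytotoxicity working notes

The compounds below may be only part of what the source reports. "The series", "measured", "known", "first", "only" and "open" are said of these compounds alone.

Compound 1 `CCCC(=O)C1=C(O)/C(=C/c2ccccc2)N(C(C)=O)C1=O` stands only as a limit in an ADME assay on HEK293 cells (Homo sapiens) for cytotoxicity; on this read-out lower numbers stand for higher toxicity in this test and higher numbers for lower toxicity in this test: compound 1 gives > 32 ug/mL, which is a limit of the assay and not a number. Compound 2 `CCCCCCCC(=O)C1=C(O)/C(=C/c2ccccc2)N(C(C)=O)C1=O` carries butyl in place of hydrogen on the acyl chain; in this assay compound 2 gives > 32 ug/mL, again a limit. Compound 3 `CCCCCCCCCCCCCC(=O)C1=C(O)/C(=C/c2ccccc2)N(C(C)=O)C1=O` extends the chain further; in this assay compound 3 gives > 32 ug/mL, also a limit. (the limit of > 32 ug/mL in this assay, at which 3 of the 3 values shown sit), so nothing separates the three. The steps a step that the two limits leave unreadable from compound 1 to compound 2, a step that the two limits leave unreadable from compound 1 to compound 3 and a step that the two limits leave unreadable from compound 2 to compound 3 are all unreadable in size, and they concern the saturated chain, not the ring.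

Compound 4 `CCCC(=O)C1=C(O)/C(=C/c2ccc(OC)cc2)N(C(C)=O)C1=O` differs from compound 1 by methoxy in place of hydrogen on an aromatic carbon. Among the compounds with values here, no measured step touches the aromatic ring, so none bears on this change directly; the only guide is that every measured member sits at the limit. The expectation for this assay is no step beyond the scatter, a step that the limit leaves unreadable from compound 1 to compound 4. Compound 4 is therefore estimated at 40 ug/mL, with a range from 20 ug/mL to 100 ug/mL, and will most likely again be reported only as a limit.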

Compound 4, half-maximal cytotoxic concentration: > 32 ug/mL
Compound 4: only a limit was reported; the forecaster's own chance of this, stated with the estimate: 75%; the middle value does not contradict the limit.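

In this assay compound 4 gives > 32 ug/mL, a limit and not a number. Within the data shown here, no step from compound 1 to compound 4 can be read, as both compounds stand only as limits: the limit of > 32 ug/mL in this assay, at which 4 of the 4 values shown sit. The compounds shown leave open whether phenyl to 4-methoxyphenyl changes cytotoxicity in this assay at all, and in which direction.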